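Removing a Methyl Group from Compound 2

This account rests on a few compounds, and the source may have more. Where it says the series, first, only, none or still open, it means among the compounds named here.

For the measured compounds named here, in an in vitro ADME assay on microsomes from liver (Homo sapiens) for pharmacokinetics, read by LC-MS (on this read-out lower numbers stand for slow clearance and higher numbers for fast clearance), compound 2 `Cc1nc2c(Cl)cc(F)cc2n1-c1ccc(C(=O)NC2CC2)s1` gives 5 mL/min/kg, the only exact number so far. Compound 1 `Cc1nc2c(Cl)cccc2n1-c1ccc(C(=O)NC2CC2)s1` has only a limit in this assay, < 4 mL/min/kg. The two compounds therefore form a single measured step, an at least 1.2-fold higher number from compound 1 to compound 2 (0.09 log units; that floor lies within the scatter). That step is a fluoro in place of hydrogen on an aromatic carbon, and its floor lies within the scatter.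

Compound 3 `O=C(NC1CC1)c1ccc(-n2cnc3c(Cl)cc(F)cc32)s1` carries a different change: hydrogen in place of methyl on an aromatic carbon. Here hydrogen stands in place of methyl on an aromatic carbon. Going by the values given here, no measured step tests this change, so the data give no firm sign of direction or size, and no shift beyond the scatter is expected. The estimated change is a 1.2-fold higher number from compound 2 to compound 3 (0.08 log units; within the scatter). For compound 3, the expected clearance is 6 mL/min/kg, within an estimated range of 3 mL/min/kg to 12 mL/min/kg.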

Compound 3, clearance: 7 mL/min/kg
The estimate for compound 3 lay 1.2-fold (0.07 log units) below the measured number, and the stated range covers the measured number.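

For the compounds shown here, the methyl group sits on an aromatic carbon between two ring nitrogen atoms, and this is the first measured test of that position: in this assay, hydrogen in its place gives a 1.4-fold higher number from compound 2 to compound 3 (0.15 log units; within the scatter). At this position, then, a methyl group can give way to hydrogen without a shift that stands out from the scatter, so compound 2 and compound 3 cannot be ranked on clearance. Compound 1, the only other compound here, has a limit and not a number: the limit of < 4 mL/min/kg in this assay, at which 1 of the 3 values shown sits.

From the compounds shown here alone, what stays open is whether a different group on this carbon, such as an amine, a methoxy group or a longer chain, would move clearance beyond the scatter. One step at one position also cannot show whether the same exchange would behave alike on the core of compound 1, which lacks the fluoro.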